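Nitrogen substituent variation on the shared imide core

The compounds below may be only part of what the source reports. "The series", "measured", "known", "first", "only" and "open" are said of these compounds alone.

In an assay on FRT-Jurkat cells for inhibition of nuclear factor NF-kappa-B complex (Homo sapiens), read by flow cytometry, with a stated time of 24 h, tested at 10 uM (on this read-out lower numbers stand for less inhibition and higher numbers for more inhibition at the one concentration tested (going by the name of the read-out)), compound 2 `O=C1CCC(N2C(=O)c3ccc(Nc4ccccn4)cc3C2=O)C(=O)N1` gives 9%. Compound 1 `O=C1CCC(N2C(=O)c3ccc(Nc4ccccc4)cc3C2=O)C(=O)N1` gives 6% and compound 3 `O=C1CCC(N2C(=O)c3cccc(Nc4ccccn4)c3C2=O)C(=O)N1` gives 1%; both numbers stand within the scatter of compound 2, so the three measured compounds are not separated by this read-out, and all sit near the bottom of the range. Among the measured compounds shown here, the single step between compounds differing in one place, a number 3 percentage points higher from compound 1 to compound 2 (within the scatter), also stays within the scatter.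

Compound 4 `CN(c1ccccc1)c1ccc2c(c1)C(=O)N(C1CCC(=O)NC1=O)C2=O` carries the change (methyl(phenyl)amino in place of (pyridin-2-yl)amino on an aromatic carbon). The step from compound 1 to compound 2 bears on the ring part of this change, since it exchanged pyridin-2-yl for phenyl on the nitrogen, and it was small. For the measured compounds named here, no measured pair speaks to the methyl entering on the nitrogen or to the loss of the hydrogen-bond donor. Given only small steps and low numbers in this assay, no movement beyond the scatter is expected; the expected step is a number 3 percentage points lower from compound 2 to compound 4 (within the scatter). Compound 4 is therefore estimated at 6%, with a range from -5% to 18%.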

Compound 4, a percentage reported as inhibition, at one concentration (the size of the read-out at that concentration, not a potency): -2%
Compound 4: the middle estimate sits 8 percentage points above what was measured; the measured number falls inside the stated range.
By their numbers in this assay, from the lowest: compounds 4, 3, 1 and 2 (each within the scatter of the next, the first and the last beyond it).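

In this assay, among the compounds shown here, the exchange of (pyridin-2-yl)amino for methyl(phenyl)amino on this aromatic carbon gives the first step beyond the scatter (a number 11 percentage points lower from compound 2 to compound 4 (beyond the scatter)), though a modest one at the low end of the read-out. Each part taken alone stays within the scatter, both the methyl on the nitrogen (a number 8 percentage points lower from compound 1 to compound 4 (within the scatter)) and the ring exchange (a number 3 percentage points higher from compound 1 to compound 2 (within the scatter)), so only the two changes together separate compounds here. No measurement available gives a reason for this step.

Open, as far as these compounds go, is whether a methyl on the nitrogen of compound 2, with the pyridin-2-yl ring kept, would move the number on its own. Also open, from the compounds shown here alone, is how a longer chain such as ethyl on that nitrogen, or a carboxylic acid on the phenyl ring, would read at this position.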